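Series notes: aryl change from compound 1 to compound 4

The compounds below may be only part of what the source reports. "The series", "measured", "known", "first", "only" and "open" are said of these compounds alone.

Measured in an assay on mitochondria (strain BALB/c) for inhibition of glycerol-3-phosphate acyltransferase 1, mitochondrial (Mus musculus), read by scintillation counting, with a stated time of 10 min; a lower number here means a stronger inhibitor, a higher number a weaker inhibitor:
compound 1 `CCCCCCCCS(=O)(=O)Nc1cc(-c2cccc(Cl)c2)ccc1C(=O)O` gives 13800 nM
compound 2 `CCCCCCCCS(=O)(=O)Nc1cc(-c2ccc(Cl)cc2)ccc1C(=O)O` gives 18100 nM
compound 3 `CCCCCCCCS(=O)(=O)Nc1cc(-c2ccc(-c3ccccc3)cc2)ccc1C(=O)O` gives 13500 nM

Compound 1 holds the second highest of the three numbers; its value lies within the scatter of compound 3 and also within the scatter of compound 2, so no order among the three can be read. The step to compound 4 `CCCCCCCCS(=O)(=O)Nc1cc(-c2ccccc2OC)ccc1C(=O)O` is 2-methoxyphenyl in place of 3-chlorophenyl on an aromatic carbon. Within the data shown here, two measured steps bear on the same aromatic carbon: a 1.3-fold higher number from compound 1 to compound 2 (0.12 log units; within the scatter) and a 1.3-fold lower number from compound 2 to compound 3 (0.13 log units; within the scatter). Both exchanged one aryl group for another there and moved the number by no more than the scatter. Among the measured compounds shown here, neither introduced a 2-methoxyphenyl, and no measured compound carries a hydrogen-bond acceptor on that ring, so this change is less well covered than the earlier ones. On the evidence, the expected step of a 1.1-fold higher number from compound 1 to compound 4 (0.04 log units; within the scatter) is small, with no direction beyond the scatter. Compound 4 is therefore estimated at 15000 nM, with a range from 6000 nM to 40000 nM in this assay.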

Compound 4, half-maximal inhibitory concentration: 16100 nM
Compound 4: middle estimate off by 1.1-fold (0.03 log units), on the low side; the range from low to high includes it.
By their numbers in this assay, from the lowest: compounds 3, 1, 4 and 2 (each within the scatter of the next).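

In this assay, 2-methoxyphenyl places a hydrogen-bond acceptor on this ring for the first time among the compounds shown, and neither new step leaves the scatter (a 1.2-fold higher number from compound 1 to compound 4 (0.07 log units; within the scatter); a 1.1-fold lower number from compound 2 to compound 4 (0.05 log units; within the scatter)). The position, on an aromatic carbon para to a carboxy group, therefore tolerates the exchange of a chlorine-bearing aryl group for one bearing methoxy, with no measurable change in this assay. Nothing on hand explains why these numbers stay so close.

It remains open whether an amine or a carboxylic acid on this aryl ring would move the number beyond the scatter, as no group shown has yet done so. A hydrogen or a methyl group at this aromatic carbon, in place of any aryl group, would show whether the aryl ring matters here at all.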